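A few compounds are considered here, and "the series" means these few. Any claim that something is new, unique, unknown or untested is made for them only; others in the source may bear on it.

In an ADME assay on L02 cells (Homo sapiens) for cytotoxicity, read by MTT assay (on this read-out lower numbers stand for stronger inhibition and higher numbers for weaker inhibition), compound 1 (`COc1ccc(/C=C/C(=O)c2ccc(OC)c3c2OC(C)(C)C=C3)cc1O`) gives > 10000 nM, which is a limit of the assay and not a number. Compound 2 (`COc1cccc(C(=O)Oc2cc(/C=C/C(=O)c3ccc(OC)c4c3OC(C)(C)C=C4)ccc2OC)c1`) carries a (3-methoxyphenyl)carbonyl in place of the hydrogen on an oxygen on an aromatic ring of compound 1. Compound 2 gives > 10000 nM, and this too is a limit. Within the data shown here, compound 2 therefore has no exact position on the scale, and the only other value shown is also a limit.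

Compound 3 (`COc1ccc(/C=C/C(=O)c2ccc(OC)c3c2OC(C)(C)C=C3)cc1OC(=O)c1ccc(Br)cc1`) keeps the shared core and the ester, but has 4-bromophenyl in place of 3-methoxyphenyl on a carbonyl carbon.

Among the measured compounds shown here, only one measured step bears on this change, and it is a step that the two limits leave unreadable from compound 1 to compound 2. It offers no size to carry forward and no direction. The expectation rests instead on (the limit of > 10000 nM in this assay, at which 2 of the 2 values shown sit). No step beyond the scatter is expected in this assay, and the expected step is a step that the limit leaves unreadable from compound 2 to compound 3. Compound 3 is expected to remain weak there, quite possibly reported only as a limit. For compound 3 the estimated value is 20000 nM, with an estimated range of 10000 nM to 50000 nM.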

Compound 3, half-maximal inhibitory concentration: 8400 nM
For compound 3 the middle estimate is 2.4-fold (0.38 log units) above the measured one; measured number below the stated range.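

In this assay, among these compounds, compound 3 gives 8400 nM, which makes it the only one of the three compounds with a number rather than a limit, so this position on the carbonyl carbon now has one exact reading. Putting 4-bromophenyl in place of 3-methoxyphenyl gives an at least 1.1-fold lower number from compound 2 to compound 3 (0.07 log units; that floor lies within the scatter), and putting (4-bromophenyl)carbonyl in place of hydrogen on an oxygen on an aromatic ring gives an at least 1.1-fold lower number from compound 1 to compound 3 (0.07 log units; that floor lies within the scatter), so neither step is shown to exceed the usual scatter of the assay and neither change can be said to add real cytotoxicity. The number therefore stands alone, with only limits around it: the limit of > 10000 nM in this assay, at which 2 of the 3 values shown sit.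

On these data alone, the true size of both steps remains open beyond those floors, and the step between the two compounds that sit at the limit cannot be read at all. Also open, as far as these compounds go, is how the reading in this assay would respond to an amine or a carboxylic acid in place of 4-bromophenyl on a carbonyl carbon, or to a longer chain there.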